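Swapping fluoro for phenyl on a pyridine ether azetidine

The source may report more compounds than this note shows. Statements on the series, on what has been measured and on what is new or still open speak of the compounds shown alone.

Compound 1 `Fc1ccc(OC[C@@H]2CCN2)cn1` gives the lowest number of the three measured compounds, 0.057 nM in an assay on brain for binding affinity to Neuronal acetylcholine receptor; alpha4/beta2 (Rattus norvegicus), read by radioligand binding; on this read-out lower numbers stand for stronger inhibition and higher numbers for weaker inhibition. Compound 2 `CCc1ccc(OC[C@@H]2CCN2)cn1` gives 19 nM and compound 3 `COc1ccc(OC[C@@H]2CCN2)cn1` gives 1.3 nM in this assay. Compound 4 `c1ccc(-c2ccc(OC[C@@H]3CCN3)cn2)cc1` differs from compound 1 in one place: phenyl in place of fluoro on an aromatic carbon. Among the compounds with values here, two measured steps bear on this change, both replacing the same fluoro: a 330-fold higher number from compound 1 to compound 2 (2.52 log units; beyond the scatter) and a 23-fold higher number from compound 1 to compound 3 (1.36 log units; beyond the scatter). Both moved far beyond the scatter toward weaker binding, and ethyl, a carbon-only group like phenyl, gave the larger loss. A large loss is therefore expected for compound 4 as well, estimated as a 530-fold higher number from compound 1 to compound 4 (2.72 log units; beyond the scatter). Compound 4 is expected to give 30 nM in this assay, within a range from 3 nM to 300 nM.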

Compound 4, inhibition constant: 2.3 nM
For compound 4 the middle estimate is 13-fold (1.12 log units) above the measured one, and the stated range ends above it.
By their numbers in this assay, from the lowest: compound 1; then compounds 3 and 4 (each within the scatter of the next); then compound 2.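

In this assay, fluoro keeps its lead over phenyl (a 40-fold higher number from compound 1 to compound 4 (1.61 log units; beyond the scatter)), yet phenyl does better than ethyl (an 8.3-fold lower number from compound 2 to compound 4 (0.92 log units; beyond the scatter)), so across compound 2 and compound 4 more heavy atoms at this position do not simply mean weaker binding. Phenyl and methoxy cannot be told apart here (a 1.8-fold higher number from compound 3 to compound 4 (0.25 log units; within the scatter)). Nothing measured here explains these differences.

Going by these compounds, whether an amine or a carboxylic acid at this position would bind as well as phenyl remains open. So does how a longer chain would compare with ethyl.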